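Aryl swap on the spiro core: chloropyridyl to fluorophenyl

The source may hold more compounds than are shown below. What is called first, only, known or untested is meant among the compounds shown, and "the series" means these compounds.

Measured in an assay on CHO cells for displacement of a labelled ligand from Glucagon receptor (Homo sapiens), read by scintillation counting, with a stated time of 60 min; on this read-out higher numbers stand for weaker inhibition and lower numbers for stronger inhibition:
compound 1 `C[C@H](c1ccc(C(=O)NCCC(=O)O)cc1)N1C(=O)C(c2cccc(F)c2)=N[C@]12CC[C@@H](C(C)(C)C)CC2` gives 490 nM
compound 2 `CC(C)(C)CC[C@H](c1ccc(C(=O)NCc2nn[nH]n2)cc1)N1C(=O)C(c2cncc(Cl)c2)=N[C@]12CC[C@@H](C(C)(C)C)CC2` gives 38 nM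
compound 3 `CC(C)CC[C@H](c1ccc(C(=O)NCc2nn[nH]n2)cc1)N1C(=O)C(c2cc(Cl)cc(Cl)c2)=N[C@]12CC[C@@H](C(C)(C)C)CC2` gives 22 nM

Compound 2 holds the second highest of the three numbers. Its gap to compound 3 is within the scatter, so no order between those two is claimed. Its gap to compound 1 is beyond the scatter, compound 1 carrying the higher number; compound 1 differs from compound 2 in more than one place, so it says nothing on its own about the aryl group.

Compound 4 `CC(C)(C)CC[C@H](c1ccc(C(=O)NCc2nn[nH]n2)cc1)N1C(=O)C(c2ccc(F)cc2)=N[C@]12CC[C@@H](C(C)(C)C)CC2` is the next step: 4-fluorophenyl in place of 5-chloropyridin-3-yl on a carbon with a double bond to nitrogen. Among the compounds with values here, no measured pair shows this exact change, so the size of the step rests on expectation only. The leaving group carries the one hydrogen-bond acceptor counted on it, the entering group none; a modest weakening is expected rather than none. Compound 4 is estimated at 75 nM in this assay, with a range of 25 nM to 220 nM. The step from compound 2 to compound 4 is expected to be a 2.0-fold higher number from compound 2 to compound 4 (0.30 log units; within the scatter).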

Compound 4, half-maximal inhibitory concentration: 13 nM
Compound 4: the middle estimate sits 5.8-fold (0.76 log units) above what was measured; measured number outside the range, below it.
By their numbers in this assay, from the lowest: compounds 4, 3 and 2 (each within the scatter of the next, the first and the last beyond it); then compound 1.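

In this assay, the carbon with a double bond to nitrogen now has its first single-place comparison: 4-fluorophenyl in place of 5-chloropyridin-3-yl gives a 2.9-fold lower number from compound 2 to compound 4 (0.47 log units; beyond the scatter). This pair shows that the hydrogen-bond acceptor counted on 5-chloropyridin-3-yl is not required for a low number at this position, since the entering group has none and still carries the lower number. No measurement here accounts for the size or direction of this step.

The change replaces the ring nitrogen and swaps chlorine for fluorine in one move, so the pair cannot assign the step to either. An unsubstituted phenyl, a 4-chlorophenyl or a 5-fluoropyridin-3-yl on the same core would be needed to separate the two contributions.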